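Trimming the Hydroxyalkyl Chain on a Triazole Substituent

The compounds below may be only part of what the source reports. "The series", "measured", "known", "first", "only" and "open" are said of these compounds alone.

Two compounds share one core and differ only at the chain on the triazole ring. Compound 1, `CCCc1cn(C(c2ccccc2)c2cc3cc(Br)ccc3nc2OC)nn1`, carries a propyl chain there; compound 2, `COc1nc2ccc(Br)cc2cc1C(c1ccccc1)n1cc(CCO)nn1`, carries a 2-hydroxyethyl chain. In an ADME assay on HeLa cells (Homo sapiens) for cytotoxicity, read by sulforhodamine B assay, with a stated time of 48 h, tested at 10 uM (on this read-out higher numbers stand for more inhibition at the one concentration tested (going by the name of the read-out) and lower numbers for less inhibition), compound 1 gives -2.25%, and in the same assay compound 2 gives 0.85%. Among the compounds with values here, of the two numbers, the one for compound 2 is at the top, yet a number 3.1 percentage points higher from compound 1 to compound 2 (within the scatter), so the two compounds in effect read alike and neither can be called the more cytotoxic.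

Compound 3, `COc1nc2ccc(Br)cc2cc1C(c1ccccc1)n1cc(CO)nn1`, shortens that chain by one carbon: hydroxy in place of hydroxymethyl on a saturated chain carbon bound to an aromatic carbon. Within the data shown here, the only measured step that bears on this is the one at the same chain, where a number 3.1 percentage points higher from compound 1 to compound 2 (within the scatter) changed little. Since altering this chain left the read-out in this assay essentially untouched, the expected step of a number 0.9 percentage points lower from compound 2 to compound 3 (within the scatter) is none beyond the scatter. Compound 3 is therefore estimated at 0%, with a range from -10% to 10%.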

Compound 3, a percentage reported as inhibition, at one concentration (the size of the read-out at that concentration, not a potency): 0.25%
Beside the measured number, compound 3's estimate is 0.3 percentage points below it, and the stated range covers the measured number.
By their numbers in this assay, from the lowest: compounds 1, 3 and 2 (each within the scatter of the next).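

In this assay, trimming the 2-hydroxyethyl chain to hydroxymethyl gives a number 0.6 percentage points lower from compound 2 to compound 3 (within the scatter) and setting hydroxymethyl against the propyl chain of compound 1 gives a number 2.5 percentage points higher from compound 1 to compound 3 (within the scatter) at the same position on the triazole. The earlier pair compared only two chains, whereas this position now has three, with and without a hydroxy group and with a shorter hydroxyalkyl chain among them, and all three read alike at the one concentration tested. Nothing here offers a reason why these numbers sit so close together.

Whether this flat picture holds for a chain ending in an amine or a carboxylic acid, or for a much longer alkyl chain, stays open, since every group shown here is a small chain that carries at most a hydroxy group. All three numbers also lie close to no inhibition at all, so these compounds leave open whether any group at this position, or any change elsewhere on the shared core, would give a clear reading in this cell test.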